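Carboxy in Place of Carbamoyl on the Cyclohexyl Ring

A few compounds are considered here, and "the series" means these few. Any claim that something is new, unique, unknown or untested is made for them only; others in the source may bear on it.

Compound 1, `Cc1cc2c(cc1Cc1ccc(C(=O)NCC3CCCCC3)o1)C(C)(C)CCC2(C)C`: 180 nM
Compound 2, `Cc1cc2c(cc1Cc1ccc(C(=O)NC[C@H]3CC[C@H](C(N)=O)CC3)o1)C(C)(C)CCC2(C)C`: 13 nM

Of the compounds shown here, two sharing one core have been tested in an assay on isolated protein for binding affinity to Gonadotropin-releasing hormone receptor (Homo sapiens); a higher number here means a weaker inhibitor, a lower number a stronger inhibitor. Compound 1 gives 180 nM, the higher of the two numbers, so it is the weaker binder of the pair. Compound 2 gives 13 nM. Among the measured compounds shown here, the only measured step between them is a 14-fold lower number from compound 1 to compound 2 (1.14 log units; beyond the scatter), a clear gain in binding from adding a carbamoyl group to the cyclohexyl ring.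

Compound 3, `Cc1cc2c(cc1Cc1ccc(C(=O)NC[C@H]3CC[C@H](C(=O)O)CC3)o1)C(C)(C)CCC2(C)C`, has not been measured. It differs from compound 1 by carboxy in place of hydrogen on a saturated ring carbon, a group placed exactly where compound 2 carries its carbamoyl. The step that bears on it is therefore a 14-fold lower number from compound 1 to compound 2 (1.14 log units; beyond the scatter). For the measured compounds named here, since a group occupying the same place in compound 2 gave a 14-fold lower number from compound 1 to compound 2 (1.14 log units; beyond the scatter), a lower number is expected for compound 3 as well, though with only one related example the size of the gain is uncertain and may fall short of that seen with carbamoyl.

Compound 3 is expected to give 30 nM, with a range from 8 nM to 120 nM. The expected step is a 6.0-fold lower number from compound 1 to compound 3 (0.78 log units; beyond the scatter).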

Compound 3, inhibition constant: 250 nM
Compound 3: middle estimate off by 8.3-fold (0.92 log units), on the low side; measured number above the stated range.
By their numbers in this assay, from the lowest: compound 2; then compounds 1 and 3 (each within the scatter of the next).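

In this assay, this position on the saturated ring does not reward just any added group: compound 3, with carboxy there, sits level with the unsubstituted compound 1 (a 1.4-fold higher number from compound 1 to compound 3 (0.14 log units; within the scatter)). Among the compounds shown here, the more telling comparison is the single swap of hydroxy in place of amino on the carbonyl carbon, which gives a 19-fold higher number from compound 2 to compound 3 (1.28 log units; beyond the scatter) and takes away the whole gain that carbamoyl brought. Binding at this position therefore depends on the exact group at the end of the ring substituent and not merely on a carbonyl being present, but no measurement offered here explains the contrast between the two groups.

Going by these compounds, with only hydrogen, carbamoyl and carboxy at this ring carbon, it remains open whether a methyl ester, a methyl-substituted amide, a hydroxymethyl group or a simple amine would behave like carbamoyl or like carboxy. Also open, on these data alone, is whether carbamoyl would keep its gain on a longer chain, set further out from the ring.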